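This account rests on a few compounds, and the source may have more. Where it says the series, first, only, none or still open, it means among the compounds named here.

Within the data shown here, in an ADME assay on microsomes from liver (Rattus norvegicus) for metabolic stability (on this read-out higher numbers stand for a longer-lived compound and lower numbers for a shorter-lived compound), compound 2 (`CC(C)C(c1ccc(-c2ccc3cccc(F)c3c2)[nH]c1=O)C1NC(=O)NC1=O`) gives 0.145 h, the only actual number so far. Compound 1 (`CC(C)C(CC1C(=O)NC(=O)N1C)c1ccc(-c2ccc3cccc(F)c3c2)[nH]c1=O`) reports only a limit of the assay, < 0.0667 h. Compound 3 (`C/C(=C1/OC(=O)NC1=O)C(c1ccc(-c2ccc3cccc(F)c3c2)[nH]c1=O)C(C)C`) keeps the shared core but changes the group on a saturated chain carbon bound to an aromatic carbon and a saturated chain carbon: a group of 9 heavy atoms (5 carbon, 1 nitrogen, 3 oxygen; one five-membered non-aromatic ring with 2 hetero atoms) in place of a group of 7 heavy atoms (3 carbon, 2 nitrogen, 2 oxygen; one five-membered non-aromatic ring with 2 hetero atoms), on a saturated chain carbon bound to an aromatic carbon and a saturated chain carbon. Among the measured compounds shown here, only one measured step bears on this place, an at least 2.1-fold higher number from compound 1 to compound 2 (0.33 log units; beyond the scatter), and it starts from a limit, so its true size stays open. Like compound 1, compound 3 carries a larger group here than compound 2, so on the strength of an at least 2.1-fold higher number from compound 1 to compound 2 (0.33 log units; beyond the scatter) a slight fall in this assay is expected, though one step is thin support. The expected change is a 1.3-fold lower number from compound 2 to compound 3 (0.12 log units; within the scatter), not clearly beyond the scatter. For compound 3 the estimated half-life is 0.11 h, with an expected range of 0.05 h to 0.3 h.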

Compound 3, half-life: > 3 h
Compound 3: no number, only a limit; the forecaster's own chance of this, stated with the estimate: 30%; at least 27-fold (1.43 log units) between middle value and limit.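

Compound 3 reaches only a limit of this assay, > 3 h, and not a number. Even so, the place on a saturated chain carbon bound to an aromatic carbon and a saturated chain carbon proves far more responsive than the one earlier step showed, with an at least 20-fold higher number from compound 2 to compound 3 (1.31 log units; beyond the scatter). Heavy-atom count alone does not order the read-out here: two groups of 9 heavy atoms still give an at least 44-fold higher number from compound 1 to compound 3 (1.65 log units; beyond the scatter), and compound 3 goes against the earlier link between the larger group and the lower number.

From the compounds shown here alone, neither new step has a true size, only a floor: the limit of > 3 h in this assay, at which 1 of the 3 values shown sits. Which part of the entering group carries the rise stays open, and so does whether a carboxylic acid at this place would hold the half-life.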